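Phenoxy-pyridine N-oxides: methyl for methoxy step

The compounds below may be only part of what the source reports. "The series", "measured", "known", "first", "only" and "open" are said of these compounds alone.

Measured so far in a functional assay on the whole organism with Mus musculus as the target, in the maximal electroshock model, with a stated time of 30 min; a higher number here means that more compound is needed for the effect, a lower number that less compound is needed:
- compound 1 `Cc1cc[n+]([O-])cc1Oc1ccccc1` gives 30 mg/kg
- compound 2 `COc1ccc(Oc2c[n+]([O-])ccc2C)cc1` gives 300 mg/kg

Compound 2 stands highest of the two numbers; its nearest neighbour is compound 1, with a 10-fold higher number from compound 1 to compound 2 (1.00 log units; beyond the scatter) separating them. Compound 3 `Cc1ccc(Oc2c[n+]([O-])ccc2C)cc1` is not yet measured. Its change from compound 2: methyl in place of methoxy on an aromatic carbon. Among the measured compounds shown here, only the step from compound 1 to compound 2 bears on this, showing that adding methoxy at this carbon raised the number. Since methyl sits between hydrogen and methoxy in what it adds, a partial reversal is expected: a 3.0-fold lower number from compound 2 to compound 3 (0.48 log units; beyond the scatter). Compound 3 is estimated at 100 mg/kg, with a range of 30 mg/kg to 300 mg/kg.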

Compound 3, minimum effective dose: 300 mg/kg
For compound 3 the middle estimate is 3.0-fold (0.48 log units) below the measured one; the measured number falls inside the stated range.
By their numbers in this assay, from the lowest: compound 1; then compounds 2 and 3 (each within the scatter of the next).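

In this assay methyl in place of methoxy on this aromatic carbon gives no change at the digits printed from compound 2 to compound 3 (within the scatter) and so the higher number is not particular to methoxy. Methyl in place of hydrogen gives a 10-fold higher number from compound 1 to compound 3 (1.00 log units; beyond the scatter) at the same carbon, so both substituents shown here part from hydrogen in the same direction. Nothing available accounts for this result.

Going by these compounds, whether a fluorine, an amine or a carboxylic acid on this carbon stays with compound 1 or with compound 3 remains open. Also open, on these data alone, is whether methyl behaves the same way on other carbons of this ring.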